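The compounds below may be only part of what the source reports. "The series", "measured", "known", "first", "only" and "open" are said of these compounds alone.

Measured so far in a functional assay on MCF7 cells (Homo sapiens) for cytotoxicity, read by MTT assay, with a stated time of 72 h; a higher number here means a weaker inhibitor of growth, a lower number a stronger inhibitor of growth:
compound 1, `C[Se]/C(=N\C(=O)c1ccco1)NC(=O)c1ccco1`, gives 88900 nM.
compound 2, `CS/C(=N\C(=O)c1ccco1)NC(=O)c1ccco1`, reaches only a limit of the assay, > 100000 nM.
compound 3, `CS/C(=N\C(=O)c1cc(-c2ccccc2)nc2ccccc12)NC(=O)c1cc(-c2ccccc2)nc2ccccc12`, gives 87700 nM.

Compound 1 and compound 2 share one core, while compound 3 is built on another; the difference between the two cores is not broken down here. The value of compound 2 is a limit, not a number: it sits at the limit of > 100000 nM in this assay, at which 1 of the 3 values shown sits. The values of compound 1 and compound 3 lie within the usual scatter of each other, so nothing separates them.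

Going by the values given here, the one measured step is the change from compound 2 to compound 1, (a group of 2 heavy atoms (1 carbon, 1 selenium; no ring) in place of a group of 2 heavy atoms (1 carbon, 1 sulfur; no ring), on a carbon with a double bond to nitrogen). It gave an at least 1.1-fold lower number from compound 2 to compound 1 (0.05 log units; that floor lies within the scatter).

Compound 4, `C[Se]/C(=N\C(=O)c1cc(-c2ccccc2)nc2ccccc12)NC(=O)c1cc(-c2ccccc2)nc2ccccc12`, is not yet measured in this assay. It carries the same change, now on the core of compound 3: a group of 2 heavy atoms (1 carbon, 1 selenium; no ring) in place of a group of 2 heavy atoms (1 carbon, 1 sulfur; no ring), on a carbon with a double bond to nitrogen. Both places read the same, so this is the same change, not merely the same kind. The step is expected to be a 1.2-fold lower number from compound 3 to compound 4 (0.07 log units; within the scatter), close to an at least 1.1-fold lower number from compound 2 to compound 1 (0.05 log units; that floor lies within the scatter), which itself did not clear the scatter. For compound 4 the estimate is 75000 nM, expected to fall between 35000 nM and 100000 nM.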

Compound 4, concentration for total growth inhibition: 7520 nM
For compound 4 the middle estimate is 10-fold (1.00 log units) above the measured one, and the stated range ends above it.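

Replacing methylsulfanyl with the selenium-bearing group, on a carbon with a double bond to nitrogen, gave a 12-fold lower number from compound 3 to compound 4 (1.07 log units; beyond the scatter) in this assay, so on the core of compound 3 this single swap has a large effect on the measured number. As far as these compounds go, compound 2 reaches only a limit of the assay, > 100000 nM, and is not a true number, so the size of its step to compound 1 remains unknown. The result therefore does not show that the change carries over from one core to the other with the same size, nor that its size differs between them: the same change on two cores in this assay, an at least 1.1-fold lower number (0.05 log units; that floor lies within the scatter) from compound 2 to compound 1 and a 12-fold lower number (1.07 log units; beyond the scatter) from compound 3 to compound 4; the limit leaves it open whether they differ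

The compounds shown leave open whether a large step would also appear on a third core, since only two cores carry this swap here. They also leave open how a longer chain such as ethylsulfanyl, or an amine, on the same carbon would read in this assay.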